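Trifluoromethyl position on the pyridinylamine arm

This account rests on a few compounds, and the source may have more. Where it says the series, first, only, none or still open, it means among the compounds named here.

Measured compounds, in a functional assay on CHO cells for antagonist activity at Orexin/Hypocretin receptor type 1 (Homo sapiens), read by FLIPR and calcium flux; a lower number here means a less potent compound, a higher number a more potent compound, by a factor of ten per unit of this negative logarithm:
compound 1 `Cc1ccc(-c2ncccn2)c(C(=O)N2CC3(CC3)C[C@H]2CNc2ccc(C(F)(F)F)cn2)n1` gives 8.4
compound 2 `Cc1ccc(-c2nccs2)c(C(=O)N2CC3(CC3)C[C@H]2CNc2ccc(C(F)(F)F)cn2)n1` gives 8.6
compound 3 `Cc1ccc(-c2ccccc2)c(C(=O)N2CC3(CC3)C[C@H]2CNc2ccc(C(F)(F)F)cn2)n1` gives 8.6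

The three numbers sit close together. Among the measured compounds shown here, compound 1 is the one with the smallest number as written, but a number 0.20 log units higher from compound 1 to compound 2 (within the scatter) and a number 0.20 log units higher from compound 1 to compound 3 (within the scatter) are both inside the scatter, and so is no change at the digits printed from compound 2 to compound 3 (within the scatter); the three compounds cannot be told apart in this assay.

Compound 4 `Cc1ccc(-c2ncccn2)c(C(=O)N2CC3(CC3)C[C@H]2CNc2cc(C(F)(F)F)ccn2)n1` has not been measured. It differs from compound 1 only in the aryl on the amine nitrogen: 4-(trifluoromethyl)pyridin-2-yl in place of 5-(trifluoromethyl)pyridin-2-yl on an amine nitrogen. The two compounds have the same atoms, joined differently.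

For the measured compounds named here, none of the measured steps bears on this change. Going by the values given here, the three steps known so far all swap the aryl attached to the core (pyrimidin-2-yl, 1,3-thiazol-2-yl, phenyl) and leave the pyridinylamine arm untouched; no pair in the set varies the trifluoromethyl position on that pyridine. The expectation therefore rests on compound 1 alone, with a wide range to reflect the lack of a bearing step. Compound 4 is expected to give about 8.3, within 7.5 to 9. The expected step is a number 0.10 log units lower from compound 1 to compound 4 (within the scatter), that is, no change beyond the scatter is assumed.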

Compound 4, negative logarithm of the antagonist equilibrium constant: 6
The estimate for compound 4 lay 2.30 log units above the measured number, outside the stated range (below it).
By their numbers in this assay, from the lowest: compound 4; then compounds 1, 2 and 3 (each within the scatter of the next).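

Trifluoromethyl position on the pyridine of the amine arm matters in this assay: with 4-(trifluoromethyl)pyridin-2-yl in place of 5-(trifluoromethyl)pyridin-2-yl on the amine nitrogen, the result is a number 2.40 log units lower from compound 1 to compound 4 (beyond the scatter), although the two groups have the same atoms and the same counts of rings, donors and acceptors. Among the compounds shown here, the earlier compounds varied only the aryl attached to the core and could not be told apart, so this arm is the first place in the set where a single change reaches beyond the scatter, and the step is large. Nothing at hand gives a reason for the drop.

This rests on one pair, so the compounds shown do not tell whether the same change would cost as much with the 1,3-thiazol-2-yl or phenyl groups of compound 2 and compound 3 on the core. They also leave open what a methyl group, a chlorine atom or a nitrile would give in place of the trifluoromethyl, and what an unsubstituted pyridin-2-yl would give on the same amine nitrogen.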